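A few compounds are considered here, and "the series" means these few. Any claim that something is new, unique, unknown or untested is made for them only; others in the source may bear on it.

Values in an ADME assay on L6 cells (Rattus norvegicus) for cytotoxicity, read by resazurin assay, with a stated time of 72 h (on this read-out higher numbers stand for weaker inhibition and lower numbers for stronger inhibition), for the three measured compounds:
Compound 1 `COc1cccc(C(O)(c2ccc(Cl)cc2)c2cccnc2)c1` gives 85600 nM
Compound 2 `CC(C)Oc1cccc(C(O)(c2ccc(Cl)cc2)c2cccnc2)c1` gives 67600 nM
Compound 3 `OC(c1ccc(Cl)cc1)(c1cccnc1)c1cccc(Br)c1` gives 54100 nM

Compound 3 stands within the scatter of both other compounds, so these numbers set no order among the three. The next structure, compound 4 `OC(c1ccc(Cl)cc1)(c1cccnc1)c1cccc(C(F)(F)F)c1`, has trifluoromethyl in place of bromo on an aromatic carbon. For the measured compounds named here, three measured steps bear on this change. Two exchanged the group on that same aromatic carbon, giving a 1.6-fold lower number from compound 1 to compound 3 (0.20 log units; within the scatter) and a 1.2-fold lower number from compound 2 to compound 3 (0.10 log units; within the scatter) as the outcomes. The third changed the group on the oxygen, giving a 1.3-fold lower number from compound 1 to compound 2 (0.10 log units; within the scatter) as its outcome. All three stayed small, although none of them involves trifluoromethyl. In this assay no step beyond the scatter is therefore expected, and the measured steps suggest no clear direction. The estimated change is a 1.1-fold higher number from compound 3 to compound 4 (0.04 log units; within the scatter) and would remain a small one. The expected value for compound 4 is 60000 nM, with an estimated range from 35000 nM to 100000 nM.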

Compound 4, half-maximal inhibitory concentration: 60400 nM
The estimate for compound 4 lay 1.0-fold (0.00 log units) below the measured number; measured number inside the range.
By their numbers in this assay, from the lowest: compounds 3, 4, 2 and 1 (each within the scatter of the next).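

In this assay, trifluoromethyl brings 4 heavy atoms onto this aromatic carbon, meta to a large group, where bromo had 1, yet the step stays within the scatter (a 1.1-fold higher number from compound 3 to compound 4 (0.05 log units; within the scatter)). Its exchange for either group linked through oxygen is also within the scatter (a 1.1-fold lower number from compound 2 to compound 4 (0.05 log units; within the scatter); a 1.4-fold lower number from compound 1 to compound 4 (0.15 log units; within the scatter)), so methoxy, isopropoxy, bromo and trifluoromethyl are not separated from one another at this position, and nothing shown offers an explanation for this flat result.

From the compounds shown here alone, it remains open whether an amine or a carboxylic acid on this aromatic carbon would give a step beyond the scatter. Also open, going by these compounds, is whether a change elsewhere on the shared core, such as replacing the chloro group, would do so.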